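Swapping a Benzodioxin for Naphthalene on a Sulfonamide Chain

This account rests on a few compounds, and the source may have more. Where it says the series, first, only, none or still open, it means among the compounds named here.

Three measured compounds share one core and differ only in the group carried on a saturated chain carbon bound to an amine nitrogen. In a functional assay on MCF7 cells (Homo sapiens) for inhibition, read by MTT assay, with a stated time of 72 h (on this read-out lower numbers stand for stronger inhibition of growth and higher numbers for weaker inhibition of growth), compound 2 `O=S(=O)(NCCCNCC1COc2ccccc2O1)c1cc(C(F)(F)F)cc(C(F)(F)F)c1` gives 2500 nM, the lowest of the three numbers. Compound 1 `O=S(=O)(NCCCNCc1ccccc1Cl)c1cc(C(F)(F)F)cc(C(F)(F)F)c1` gives 8800 nM, and compound 3 `CN(CCCNS(=O)(=O)c1cc(C(F)(F)F)cc(C(F)(F)F)c1)Cc1ccccc1` gives 16000 nM. Two steps are known: a 3.5-fold lower number from compound 1 to compound 2 (0.55 log units; beyond the scatter), and a 1.8-fold higher number from compound 1 to compound 3 (0.26 log units; within the scatter).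

Compound 4 `O=S(=O)(NCCCNCc1cccc2ccccc12)c1cc(C(F)(F)F)cc(C(F)(F)F)c1` is not yet measured. It differs from compound 2 by naphthalen-1-yl in place of 2,3-dihydro-1,4-benzodioxin-2-yl on a saturated chain carbon bound to an amine nitrogen. The step from compound 1 to compound 2 bears most directly on this change, since it too exchanges the ring group at this very place and moved the number modestly; the step from compound 1 to compound 3 touched the neighbouring amine and stayed within the scatter. With the benzodioxin leaving, the number is expected to drift back toward that of compound 1, because a 3.5-fold lower number from compound 1 to compound 2 (0.55 log units; beyond the scatter) shows that group alone accounted for the only clear gain seen. The expected step is a 2.0-fold higher number from compound 2 to compound 4 (0.30 log units; within the scatter). Compound 4 is therefore estimated at 5000 nM, within a range from 1500 nM to 16000 nM.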

Compound 4, concentration for 50% growth inhibition: 1400 nM
Estimate against measurement, compound 4: 3.6-fold (0.55 log units) above; the whole stated range lies above it.
By their numbers in this assay, from the lowest: compounds 4 and 2 (each within the scatter of the next); then compounds 1 and 3 (each within the scatter of the next).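

The naphthalen-1-yl group brings no oxygen and no hydrogen-bond acceptors, yet it lands level with the benzodioxin in this assay, with a 1.8-fold lower number from compound 2 to compound 4 (0.25 log units; within the scatter) as the measured step, so the oxygens of the 2,3-dihydro-1,4-benzodioxin-2-yl group are not required for a number in this range at this place on the chain. Among the compounds shown here, the earlier compounds could not show this, since the benzodioxin alone stood apart from 2-chlorophenyl, and the gain could have belonged to that one group; now a second, all-carbon group also clears the scatter against compound 1, with a 6.3-fold lower number from compound 1 to compound 4 (0.80 log units; beyond the scatter) as the largest step at this place so far. No measurement among those shown explains why either group gives a lower number than 2-chlorophenyl.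

Still open, on these data alone, is how far this tolerance reaches, for instance whether an amine or a carboxylic acid carried on the naphthalen-1-yl group would keep the number in this range. Also open, as far as these compounds go, is whether a longer chain, or a methyl group on the amine nitrogen of compound 4, would leave it there or move it.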